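One Methyl Less: From Compound 3 to Compound 4

A few compounds are considered here, and "the series" means these few. Any claim that something is new, unique, unknown or untested is made for them only; others in the source may bear on it.

Compound 1, `COc1cc(C)cc(-c2nn(CC#N)cc2-c2ccc(-c3cccc(C(C)=O)c3)nc2)c1`, in a functional assay on DU-145 cells (Homo sapiens) for inhibition, read by sulforhodamine B assay, with a stated time of 48 h (on this read-out lower numbers stand for higher toxicity in this test and higher numbers for lower toxicity in this test), gives > 100000 nM, which is a limit of the measurement and not a number.
Compound 2, `Cc1cc(O)cc(-c2nn(CC#N)cc2-c2ccnc(-c3ccc(Oc4ccccc4)cc3)c2)c1`, gives 26100 nM.
Compound 3, `COc1cc(C)cc(-c2nn(CC#N)cc2-c2ccnc(-c3ccc(N(C)C)cc3)c2)c1`, gives > 100000 nM, again a limit rather than a number.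

Compound 3 therefore stands at the limit of > 100000 nM in this assay, at which 2 of the 3 values shown sit, and among the three measured compounds only compound 2 gives a number at all. Among the measured compounds shown here, no pair of measured compounds differs in just one place, so no measured step is available to lean on.

Compound 4, `Cc1cc(O)cc(-c2nn(CC#N)cc2-c2ccnc(-c3ccc(N(C)C)cc3)c2)c1`, differs from compound 3 by hydrogen in place of methyl on an oxygen on an aromatic ring; cut one bond further out, the same difference reads methoxy to hydroxy. For the measured compounds named here, compound 2 carries the same hydroxy group on its outer ring and is the one compound with a number, while compound 1 and compound 3 both carry the methoxy group and both sit at the limit. This is too thin to call a pattern, but it points toward a move to lower numbers rather than none.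

Compound 4 is therefore expected to come in around 60000 nM, within 15000 nM to 200000 nM, with a step of an at least 1.6-fold lower number from compound 3 to compound 4 (0.22 log units; that floor lies within the scatter), and a real chance that the result is once more only a limit.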

Compound 4, concentration lethal to 50% of the cells: 53200 nM
The estimate for compound 4 lay 1.1-fold (0.05 log units) above the measured number; low and high end bracket the measured number.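

Taking the methyl off this oxygen gives compound 4 a real number in this assay, and the step reads an at least 1.8-fold lower number from compound 3 to compound 4 (0.27 log units; that floor lies within the scatter). This is the first comparison in which the methoxy to hydroxy change is the only difference, but it fixes only a floor, and that floor does not clear the usual variation between repeat measurements, so the true size of the change stays unknown because compound 3 itself gives only a limit: the limit of > 100000 nM in this assay, at which 2 of the 4 values shown sit.

The second comparison holds the hydroxy group fixed and gives a 2.0-fold higher number from compound 2 to compound 4 (0.31 log units; beyond the scatter), a modest change beyond the scatter, so the hydroxy group alone does not set the number and dimethylamino in place of phenoxy also moves it.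

The compounds shown leave open whether a longer chain on this oxygen, such as ethyl or propyl, or an amine standing in place of the oxygen, would shift the number in either direction. They also leave open whether the methoxy to hydroxy change would have a similar effect in a compound carrying phenoxy, where the methoxy partner of compound 2 would give the matching comparison.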